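The source may report more compounds than this note shows. Statements on the series, on what has been measured and on what is new or still open speak of the compounds shown alone.

Compound 1 `COc1ccc(/C=C/C(=O)/C=C/c2cc3ccccc3nc2Oc2ccccc2)c(OC)c1`: > 10000 nM, a limit
Compound 2 `COc1cc(OC)c(OC)cc1/C=C/C(=O)/C=C/c1cc2ccccc2nc1Oc1ccccc1`: 8030 nM
Compound 3 `COc1ccc(/C=C/C(=O)/C=C/c2cc3ccccc3nc2Oc2cccc(Cl)c2)c(OC)c1`: > 10000 nM, a limit

All three compounds were tested in a functional assay on NCI-H460 cells (Homo sapiens) for cytotoxicity, read by MTT assay, with a stated time of 48 h; a higher number here means a weaker inhibitor, a lower number a stronger inhibitor. In this assay compound 3 gives no number, only a limit: > 10000 nM. That is the limit of > 10000 nM in this assay, at which 2 of the 3 values shown sit.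

Compound 4 `COc1cc(OC)c(OC)cc1/C=C/C(=O)/C=C/c1cc2ccccc2nc1Oc1cccc(Cl)c1` differs from compound 3 in one place: methoxy in place of hydrogen on an aromatic carbon. Methoxy replaces hydrogen on an aromatic carbon, turning 2,4-dimethoxyphenyl into 2,4,5-trimethoxyphenyl. The same replacement has been measured once, as an at least 1.2-fold lower number from compound 1 to compound 2 (0.09 log units; that floor lies within the scatter). The other measured step, chloro in place of hydrogen, is a step that the two limits leave unreadable from compound 1 to compound 3, so it adds no size to work with.

Among the compounds with values here, with only that one small measured step as a guide, a modest move towards a lower number is expected, and it may not exceed the scatter. This expectation leans on compound 2 at 8030 nM. The expected step is an at least 1.1-fold lower number from compound 3 to compound 4 (0.07 log units; that floor lies within the scatter). The estimated value for compound 4 is 8500 nM, within an expected range of 4500 nM to 14000 nM.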

Compound 4, half-maximal inhibitory concentration: > 10000 nM
Compound 4: no number, only a limit; the forecaster's own chance of this, stated with the estimate: 40%; middle value at least 1.1-fold (0.07 log units) away from the limit.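

Compound 4 gives only a limit in this assay, so the change from 2,4-dimethoxyphenyl to 2,4,5-trimethoxyphenyl cannot be read when chloro is present, and neither can any other step between two limits. Chloro in place of hydrogen now has a readable step for the first time, on the 2,4,5-trimethoxyphenyl compounds: an at least 1.2-fold higher number from compound 2 to compound 4 (0.09 log units; that floor lies within the scatter), so it cannot be told from the scatter. Neither added group has moved a compound clearly away from the others, and the ceiling of the assay hides how large either change really is: the limit of > 10000 nM in this assay, at which 3 of the 4 values shown sit.

From the compounds shown here alone, how far compounds 1, 3 and 4 lie past their limits stays open. Also open, going by these compounds, is whether an amine or a carboxylic acid in place of the methoxy or the chloro would give a clearly lower number.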